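Removing the Chloro Group from Compound 2

This account rests on a few compounds, and the source may have more. Where it says the series, first, only, none or still open, it means among the compounds named here.

In a functional assay on HT-29 cells (Homo sapiens) for inhibition, read by MTT assay (on this read-out lower numbers stand for stronger inhibition and higher numbers for weaker inhibition), compound 1 (`N#CCC(=O)Nc1sc(C(=O)Nc2ccc(Cl)cc2)c(-c2ccccc2)c1C#N`) gives 860 nM and compound 2 (`CCOC(=O)c1c(N)sc(C(=O)Nc2ccc(Cl)cc2)c1-c1ccccc1`) gives 190 nM as the lower of the two numbers, a gap beyond the usual scatter. Compound 2 therefore stands as the stronger inhibitor of this pair. Compound 3 (`CCOC(=O)c1c(N)sc(C(=O)Nc2ccccc2)c1-c1ccccc1`) carries hydrogen in place of chloro on an aromatic carbon of compound 2, para to a large group (hydrogen in place of chloro on an aromatic carbon). The 4-chlorophenyl thus becomes phenyl, and nothing else changes. Within the data shown here, compound 1 and compound 2 differ in more than one place, and no measured pair isolates this change, so any expectation here is loose. The expected 1.6-fold higher number from compound 2 to compound 3 (0.20 log units; within the scatter) is a modest one toward a higher number, and it may not clear the scatter. For compound 3 the estimated value is 300 nM with an expected range of 100 nM to 900 nM in this assay once measured.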

Compound 3, half-maximal inhibitory concentration: 7490 nM
Compound 3: middle estimate off by 25-fold (1.40 log units), on the low side, and the stated range ends below it.
By their numbers in this assay, from the lowest: compound 2; then compound 1; then compound 3.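

Replacing the single chlorine atom with hydrogen gives a 39-fold higher number from compound 2 to compound 3 (1.60 log units; beyond the scatter) in this assay, so this place on the aromatic ring, para to a large group, is far from indifferent to what it carries. Among these compounds, no earlier pair could isolate this change, and this step ties the stronger inhibition to the chloro of the 4-chlorophenyl, although the change removes only one heavy atom and no hydrogen-bond donor, acceptor, ring or charge. Nothing available bears on why the step is so large.

On these data alone, whether chloro is specifically needed, or whether fluoro, bromo or methoxy at the same place would also keep the stronger inhibition, remains open. As far as these compounds go, it is also open whether the same change made on compound 1 would produce a step of similar size.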